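The compounds below may be only part of what the source reports. "The series", "measured", "known", "first", "only" and "open" are said of these compounds alone.

Three related compounds have been tested in a functional assay on K562 cells (Homo sapiens) for cytotoxicity, read by sulforhodamine B assay; a higher number here means a weaker inhibitor, a lower number a stronger inhibitor. Compound 1 `Cc1cn(C2[Se][C@H](CO)[C@@H](O)[C@@H]2N=[N+]=[N-])c(=O)[nH]c1=O` carries a methyl group on an aromatic carbon of its core. In this assay compound 1 gives > 100000 nM, which is a limit of the assay rather than a number. Compound 2 `[N-]=[N+]=N[C@@H]1C(n2cc(Cl)c(=O)[nH]c2=O)[Se][C@H](CO)[C@H]1O` carries a chloro group in place of that methyl. In this assay compound 2 gives > 100000 nM, again a limit. Compound 3 `[N-]=[N+]=N[C@@H]1C(n2cc(Br)c(=O)[nH]c2=O)[Se][C@H](CO)[C@H]1O` carries a bromo group there. In this assay compound 3 gives > 100000 nM, also a limit. All three values sit at the limit of > 100000 nM in this assay, at which 3 of the 3 values shown sit, so the steps a step that the two limits leave unreadable from compound 1 to compound 2, a step that the two limits leave unreadable from compound 1 to compound 3 and a step that the two limits leave unreadable from compound 2 to compound 3 cannot be sized; compound 3 stands at the limit together with the others, with no order among them. Compound 4 `[N-]=[N+]=N[C@@H]1C(n2cc(I)c(=O)[nH]c2=O)[Se][C@H](CO)[C@H]1O` is the next member of the series: iodo in place of bromo on an aromatic carbon. Each measured step exchanged one group for another on the same aromatic carbon, and none moved a value off the limit. For compound 4 the expected step is a step that the limit leaves unreadable from compound 3 to compound 4. Compound 4 is therefore expected to give 150000 nM, within a range from 50000 nM to 500000 nM, most likely reported once more as a limit.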

Compound 4, half-maximal inhibitory concentration: > 100000 nM
Compound 4: only a limit was reported (the forecaster's own chance of this, stated with the estimate: 85%); the middle value does not contradict the limit.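

Compound 4 also stands at a limit, so its steps from compound 1, compound 2 and compound 3 cannot be read, because every value sits at the same limit: the limit of > 100000 nM in this assay, at which 4 of the 4 values shown sit. The compounds shown leave open how strong any of them truly is in this assay, and whether the group on the aromatic carbon matters there at all.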